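The compounds below may be only part of what the source reports. "The series", "measured", "known", "first", "only" and "open" are said of these compounds alone.

Of the compounds shown here, three from one series have been tested in a functional assay on DU-145 cells (Homo sapiens) for antiproliferative activity, read by sulforhodamine B assay; a lower number here means a stronger inhibitor, a higher number a weaker inhibitor. Compound 1 `CCCCCCCCCCCCCCCCCCNC(=O)[C@H]1CSC(CCCCCCCCCCCC)N1` carries a dodecyl chain on the saturated ring carbon of the shared core and gives 8900 nM. Compound 2 `CCCCCCCCCCCCCCCCCCNC(=O)[C@H]1CSC(c2ccc(F)cc2)N1` bears a 4-fluorophenyl group there and gives 5700 nM. Compound 3 `CCCCCCCCCCCCCCCCCCNC(=O)[C@H]1CSC(c2ccc([N+](=O)[O-])cc2)N1` bears a 4-nitrophenyl group and gives 15300 nM, the highest of the three numbers; its gap to compound 1 is within the scatter, while its gap to compound 2, a 2.7-fold higher number from compound 2 to compound 3 (0.43 log units; beyond the scatter), is beyond it. The two steps from the dodecyl parent, a 1.6-fold lower number from compound 1 to compound 2 (0.19 log units; within the scatter) and a 1.7-fold higher number from compound 1 to compound 3 (0.24 log units; within the scatter), are both within the scatter.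

Compound 4 `CCCCCCCCCCCCCCCCCCNC(=O)[C@H]1CSC(c2ccc(F)c(Br)c2)N1` is the next member: 3-bromo-4-fluorophenyl in place of 4-nitrophenyl on a saturated ring carbon. The change that bears on it most directly is the swap between compound 2 and compound 3, where the nitro group in place of fluoro brought a 2.7-fold higher number from compound 2 to compound 3 (0.43 log units; beyond the scatter); compound 4 returns the fluoro and adds a bromo on the same ring. For the measured compounds named here, the reverse of that swap would be expected to bring the number back down to around the level of compound 2, with no measured step that tells what the added bromo does. Compound 4 is therefore expected to show a 3.1-fold lower number from compound 3 to compound 4 (0.49 log units; beyond the scatter) in this assay, and its value is estimated at 5000 nM, within a range from 2000 nM to 12000 nM.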

Compound 4, half-maximal inhibitory concentration: 11300 nM
For compound 4 the middle estimate is 2.3-fold (0.35 log units) below the measured one; the measured number falls inside the stated range.
By their numbers in this assay, from the lowest: compounds 2, 1, 4 and 3 (each within the scatter of the next, the first and the last beyond it).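

Set on the ring of compound 2, the bromo in place of hydrogen gives, in this assay, (a 2.0-fold higher number from compound 2 to compound 4 (0.30 log units; within the scatter)), the first reading of a second substituent on the phenyl ring at this position, and that step stays inside the scatter. For the compounds shown here, the exchange of 4-nitrophenyl for 3-bromo-4-fluorophenyl gives (a 1.4-fold lower number from compound 3 to compound 4 (0.13 log units; within the scatter)), and the exchange of dodecyl for the same group gives (a 1.3-fold higher number from compound 1 to compound 4 (0.10 log units; within the scatter)), so compound 4 cannot be told apart from any of the three earlier compounds, and the only step beyond the scatter at this position remains the one between compound 2 and compound 3. Nothing here gives any measured ground for the size of these steps.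

The compounds shown leave open what a hydroxyl, an amine or a carboxylic acid on the phenyl ring would do, and whether a 3-bromophenyl group without the fluoro would read like compound 4. On these data alone, all four compounds also share the same chain on the amide nitrogen, so the effect of a shorter chain there remains unknown.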